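Dropping a Methoxy Group From Compound 3

This account rests on a few compounds, and the source may have more. Where it says the series, first, only, none or still open, it means among the compounds named here.

Of the compounds shown here, three have been measured in an ADME assay on RAW264.7 cells (Mus musculus) for cytotoxicity, read by MTT assay, with a stated time of 24 h, tested at 2.5 ug/mL; on this read-out higher numbers stand for a weaker effect at the one concentration tested and lower numbers for a stronger effect. Compound 1 `COc1cccc(CCCc2cccc(O)c2)c1OC` gives 97.4%, compound 2 `COc1ccc(C(=O)CCc2ccc(OC)cc2OC)c(O)c1` gives 96.2%, and compound 3 `COc1ccc(C(=O)CCc2ccc(OC)c(OC)c2)c(O)c1` gives 89%. Compound 3 holds the smallest of the three numbers, yet the distance to compound 2 and the distance to compound 1 both lie within the scatter of this kind of measurement, so the three results are best read as one cluster of weak effects at the single concentration tested.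

Compound 4 `COc1ccc(CCC(=O)c2ccc(OC)cc2O)cc1` is not yet measured. It differs from compound 3 in one place: hydrogen in place of methoxy on an aromatic carbon. The group that leaves sits on an aromatic carbon of a six-membered ring of carbon only, and a hydrogen atom takes its place; the rest of the shared core is untouched.

No step between measured compounds has been shown, and the three values give no sign that any change among them moves the read-out beyond the scatter. The step from compound 3 to compound 4 in this assay is therefore expected to be small, a number 4 percentage points higher from compound 3 to compound 4 (within the scatter), in no clear direction. Compound 4 is estimated at 93%, with a range from 80% to 100%.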

Compound 4, a percentage reported as activity, at one concentration (the size of the read-out at that concentration, not a potency): 94.5%
Beside the measured number, compound 4's estimate is 1.5 percentage points below it; low and high end bracket the measured number.
By their numbers in this assay, from the lowest: compounds 3, 4, 2 and 1 (each within the scatter of the next).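

In this assay, the exchange of methoxy for hydrogen at this place, on an aromatic carbon of a six-membered aromatic ring of carbon only, ortho to a methoxy group and meta to a large group, gives a number 5.5 percentage points higher from compound 3 to compound 4 (within the scatter). The same kind of exchange, starting from the other methoxy pattern of compound 2, gives a number 1.7 percentage points lower from compound 2 to compound 4 (within the scatter), so both single-place steps now available stay within the scatter and the loss of either methoxy group leaves the read-out in the same cluster of weak effects. No measurement shown here offers an explanation for this result.

The compounds shown leave open whether a different group on this aromatic carbon, such as an amine, a carboxylic acid or a longer chain like butoxy, would give a step beyond the scatter. They also leave open whether the hydroxy group on the other ring, or the carbonyl shared by compound 2, compound 3 and compound 4, can be exchanged with as little consequence, and whether these small steps would persist at any other concentration.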